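Changing the aryl group of compound 2

The source may report more compounds than this note shows. Statements on the series, on what has been measured and on what is new or still open speak of the compounds shown alone.

Values in a functional assay on HepG2 cells (Homo sapiens) for antiproliferative activity, read by spectrophotometry, with a stated time of 2 days; on this read-out lower numbers stand for stronger inhibition of growth and higher numbers for weaker inhibition of growth:
- compound 1 `Cc1ccc(Nc2ncc(C(F)(F)F)c(N3Cc4cccc(N(C)S(C)(=O)=O)c4C3)n2)cc1C`: > 30000 nM, a limit
- compound 2 `Cc1ccc(Nc2ncc(C(F)(F)F)c(N3Cc4cccc(N(C)S(C)(=O)=O)c4C3)n2)c(Cl)c1`: > 30000 nM, a limit
- compound 3 `CN(c1cccc2c1CN(c1nc(Nc3cccc(Oc4ccccc4)c3)ncc1C(F)(F)F)C2)S(C)(=O)=O`: 23000 nM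

Compound 2 stands at the limit of > 30000 nM in this assay, at which 2 of the 3 values shown sit. Compound 4 `COc1cc(Nc2ncc(C(F)(F)F)c(N3Cc4cccc(N(C)S(C)(=O)=O)c4C3)n2)cc(OC)c1` differs from it in one place: 3,5-dimethoxyphenyl in place of 2-chloro-4-methylphenyl on a nitrogen on an aromatic ring. Within the data shown here, the only measured step at this place is a step that the two limits leave unreadable from compound 1 to compound 2, so it offers no size to carry over. Among the measured compounds shown here, compound 3, with another group on that nitrogen, gives 23000 nM, the only true number here. On that basis, growth inhibition in this assay is expected to stay weak, with no large gain. The expected change is an at least 1.0-fold lower number from compound 2 to compound 4 (0.02 log units; that floor lies within the scatter). For compound 4 the estimate is 28000 nM, with an expected range of 12000 nM to 60000 nM.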

Compound 4, concentration for 50% growth inhibition: 1800 nM
Beside the measured number, compound 4's estimate is 16-fold (1.19 log units) above it, and the stated range ends above it.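

In this assay, the earlier compounds gave no readable size for a change of aryl group on this nitrogen, and the step between compound 1 and compound 2 cannot be read, as both values are limits: the limit of > 30000 nM in this assay, at which 2 of the 4 values shown sit.

This position can clearly shift growth inhibition: 3,5-dimethoxyphenyl in place of 2-chloro-4-methylphenyl gives an at least 16-fold lower number from compound 2 to compound 4 (1.22 log units; beyond the scatter), and in place of 3,4-dimethylphenyl it gives an at least 16-fold lower number from compound 1 to compound 4 (1.22 log units; beyond the scatter).

On these data alone, it remains open whether a single methoxy group would give the same gain. Also open, as far as these compounds go, is how an ethoxy group, an amine or a carboxylic acid on this phenyl ring would compare.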